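Replacing (2-carboxyethyl)carbonyl with 6-chloropyridin-2-yl

The source may hold more compounds than are shown below. What is called first, only, known or untested is meant among the compounds shown, and "the series" means these compounds.

Results in a functional assay on NCI-H3255 cells (Homo sapiens) for antiproliferative activity, read by MTT assay, with a stated time of 72 h; on this read-out higher numbers stand for weaker inhibition and lower numbers for stronger inhibition:
Compound 1 `O=C(Nc1cc(Nc2ccc(Cl)cc2)ncn1)c1ccc(F)cc1`: > 30000 nM (a limit)
Compound 2 `O=C(O)CCC(=O)Nc1cc(Nc2ccc(Cl)cc2)ncn1`: 4370 nM

Going by the values given here, compound 2, at 4370 nM, carries the only actual number so far. The value of compound 1, > 30000 nM, is a limit.

Compound 3 `Clc1ccc(Nc2cc(Nc3cccc(Cl)n3)ncn2)cc1` has not yet been measured. It differs from compound 2 as follows: 6-chloropyridin-2-yl in place of (2-carboxyethyl)carbonyl on a nitrogen on an aromatic ring.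

Among the compounds with values here, only one measured step bears on this change: an at least 6.8-fold lower number from compound 1 to compound 2 (0.83 log units; beyond the scatter). It lies beyond the scatter and involves the group carried on the same nitrogen, although it is a different swap. In that step, removing an aromatic ring went with a lower number. Compound 3 brings an aromatic ring back, so a modest move to a higher number is expected in this assay, though this rests on a single step. The expected size is a 2.1-fold higher number from compound 2 to compound 3 (0.31 log units; beyond the scatter). Compound 3 is estimated at 9000 nM, within an expected range of 2000 nM to 30000 nM.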

Compound 3, half-maximal inhibitory concentration: > 30000 nM
Compound 3: a limit, no number; the forecaster's own chance of this, stated with the estimate: 25%; middle value at least 3.3-fold (0.52 log units) away from the limit.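

In this assay the swap on this nitrogen gives an at least 6.8-fold higher number from compound 2 to compound 3 (0.83 log units; beyond the scatter) and so shows that a ring bound directly to the nitrogen, with no carbonyl in the link, does not restore a measurable value. Going by these compounds alone, compound 2, with its (2-carboxyethyl)carbonyl, remains the only one of the three compounds with an actual number. Compound 3 gives a limit, not a number, and it is the same limit as for compound 1, which carries its aromatic ring through a carbonyl: the limit of > 30000 nM in this assay, at which 2 of the 3 values shown sit.

On these data alone, what remains open is whether the carboxylic acid of compound 2 matters or the chain that carries it, a question that a methyl ester or a plain butanoyl chain would address. A longer chain ending in a carboxylic acid, or a chain ending in an amine, would show how much change this nitrogen tolerates.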